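The source may report more compounds than this note shows. Statements on the series, on what has been measured and on what is new or still open speak of the compounds shown alone.

Compound 1 `Cc1ccccc1-n1nncc1CN1C(=O)C2(C(C#N)=C(N)Oc3c2c2nc4ccccc4nc2c2ccccc32)c2ccccc21` is known in a functional assay on A549 cells (Homo sapiens) for antiproliferative activity, read by MTT assay, with a stated time of 48 h (a lower number here means a stronger inhibitor, a higher number a weaker inhibitor), only as a limit: in this assay compound 1 gives > 50000 nM. Compound 2 `N#CC1=C(N)Oc2c(c3nc4ccccc4nc3c3ccccc23)C12C(=O)N(Cc1cnnn1-c1ccc(Br)cc1)c1ccccc12` in this assay gives 44300 nM. For compound 3 `N#CC1=C(N)Oc2c(c3nc4ccccc4nc3c3ccccc23)C12C(=O)N(Cc1cnnn1-c1ccc([N+](=O)[O-])cc1)c1ccccc12` this assay again returns only a limit, and compound 3 gives > 50000 nM. The move an at least 1.1-fold lower number from compound 1 to compound 2 (0.05 log units; that floor lies within the scatter) and the move an at least 1.1-fold higher number from compound 2 to compound 3 (0.05 log units; that floor lies within the scatter) both fall within the scatter, while a step that the two limits leave unreadable from compound 1 to compound 3 cannot be read, since (the limit of > 50000 nM in this assay, at which 2 of the 3 values shown sit). Compound 3 thus stands at the limit of this assay, its number unresolved. Compound 4 `N#CC1=C(N)Oc2c(c3nc4ccccc4nc3c3ccccc23)C12C(=O)N(Cc1cnnn1-c1ccc(F)c(Cl)c1)c1ccccc12` differs from it by 3-chloro-4-fluorophenyl in place of 4-nitrophenyl on an aromatic nitrogen. For the measured compounds named here, no measured step covers this change, and the measured steps were small or unreadable, so no shift beyond the scatter is expected in this assay. Compound 4 is expected to give 50000 nM, between 20000 nM and 120000 nM, a step of a number no higher from compound 3 to compound 4 (the limit leaves the size open).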

Compound 4, half-maximal inhibitory concentration: > 50000 nM
Compound 4 was reported as a limit (the forecaster's own chance of this, stated with the estimate: 60%); the middle value sits exactly at the limit.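

In this assay compound 4 also gives only a limit, > 50000 nM. For the compounds shown here, the one readable step is an at least 1.1-fold higher number from compound 2 to compound 4 (0.05 log units; that floor lies within the scatter), so a second halogen-bearing phenyl on this aromatic nitrogen shows no shift beyond the scatter. The steps to compound 4 from compound 3 and from compound 1 cannot be read, since both ends are limits: the limit of > 50000 nM in this assay, at which 3 of the 4 values shown sit.

On these data alone, whether compound 1, compound 3 and compound 4 truly differ stays open. Also open, as far as these compounds go, is what an amine or a carboxylic acid on this phenyl ring, or a longer alkyl chain in its place, would give.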